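The source may hold more compounds than are shown below. What is called first, only, known or untested is meant among the compounds shown, and "the series" means these compounds.

Measured so far in a functional assay on SK-HEP1 cells (Homo sapiens) for inhibition, read by MTT assay, with a stated time of 72 h; a lower number here means a stronger inhibitor, a higher number a weaker inhibitor:
- compound 1 `Nc1ncnc2c1c(-c1cnc3[nH]ccc3c1)nn2CCCCCCCCC(=O)NO` gives 11200 nM
- compound 2 `Nc1ncnc2c1c(-c1cnc3[nH]ccc3c1)nn2CCCCCC(=O)NO` gives > 150000 nM as a limit of the assay, not a number
- compound 3 `Nc1ncnc2c1c(-c1cnc3[nH]ccc3c1)nn2CCCCCCCCCC(=O)NO` gives 23500 nM

Of the two true numbers, compound 3 holds the higher one. Next comes compound 4 `Nc1ncnc2c1c(-c1cnc3[nH]ccc3c1)nn2CCCCCCC(=O)NO`, with the change hydroxycarbamoyl in place of 3-(hydroxycarbamoyl)propyl on a saturated chain carbon, six bonds along the chain from an aromatic nitrogen in which hydroxycarbamoyl replaces 3-(hydroxycarbamoyl)propyl. Its chain is shorter than in compound 1 and longer than in compound 2. For the measured compounds named here, two steps bear on this: the large at least 13-fold higher number from compound 1 to compound 2 (1.12 log units; beyond the scatter) and the smaller at least 6.3-fold lower number from compound 2 to compound 3 (0.80 log units; beyond the scatter). Compound 3 goes against a simple rule of longer chain, lower number, given a 2.1-fold higher number from compound 1 to compound 3 (0.32 log units; beyond the scatter) here. A modest rise is therefore expected, a 2.1-fold higher number from compound 3 to compound 4 (0.33 log units; beyond the scatter) as the estimated step. Compound 4 is estimated at 50000 nM with an expected range of 18000 nM to 140000 nM in this assay.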

Compound 4, half-maximal inhibitory concentration: 14700 nM
Compound 4: the middle estimate sits 3.4-fold (0.53 log units) above what was measured; the whole stated range lies above it.
By their numbers in this assay, from the lowest: compounds 1, 4 and 3 (each within the scatter of the next, the first and the last beyond it). At a limit, above all of these: compound 2.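

In this assay, the chain of compound 4 does not carry the loss seen with the shortest chain, as both a 1.6-fold lower number from compound 3 to compound 4 (0.20 log units; within the scatter) and a 1.3-fold higher number from compound 1 to compound 4 (0.12 log units; within the scatter) remain comparable to the longer chains. The one sharp break lies with compound 2, whose value is a limit of the assay and not a number: an at least 10-fold lower number from compound 2 to compound 4 (1.00 log units; beyond the scatter). The same change thus gives different steps at different chain lengths: the same change on two cores in this assay, an at least 13-fold higher number (1.12 log units; beyond the scatter) from compound 1 to compound 2 and a 1.6-fold lower number (0.20 log units; within the scatter) from compound 3 to compound 4, at least 21-fold (1.33 log units) apart, beyond the scatter of two such steps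

Still open, on these data alone, is whether a longer chain than in compound 3 continues the rise seen from compound 1 to compound 3. Also open, as far as these compounds go, is whether a carboxylic acid or an amine in place of the hydroxycarbamoyl keeps these numbers.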